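Shifting One Chlorine on Compound 3

A few compounds are considered here, and "the series" means these few. Any claim that something is new, unique, unknown or untested is made for them only; others in the source may bear on it.

Compound 1 (`CCCN1CCN(c2ccc(S(=O)(=O)Oc3ccccc3C)cc2)C1=O`), compound 2 (`CCCN1CCN(c2ccc(S(=O)(=O)Oc3ccc(C)cc3C)cc2)C1=O`), compound 3 (`CCCN1CCN(c2ccc(S(=O)(=O)Oc3cc(Cl)c(Cl)cc3Cl)cc2)C1=O`) and compound 4 (`CCCN1CCN(c2ccc(S(=O)(=O)Oc3c(Cl)cc(Cl)cc3Cl)cc2)C1=O`) share one core and differ only in the group on an oxygen next to the sulfonyl sulfur.

Shifting One Chlorine on Compound 3

Compound 1 (`CCCN1CCN(c2ccc(S(=O)(=O)Oc3ccccc3C)cc2)C1=O`), compound 2 (`CCCN1CCN(c2ccc(S(=O)(=O)Oc3ccc(C)cc3C)cc2)C1=O`), compound 3 (`CCCN1CCN(c2ccc(S(=O)(=O)Oc3cc(Cl)c(Cl)cc3Cl)cc2)C1=O`) and compound 4 (`CCCN1CCN(c2ccc(S(=O)(=O)Oc3c(Cl)cc(Cl)cc3Cl)cc2)C1=O`) share one core and differ only in the group on an oxygen whose other neighbour is the sulfonyl sulfur.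

In a functional assay on MCF7 cells (Homo sapiens) for antiproliferative activity, read by sulforhodamine B assay, with a stated time of 48 h (on this read-out higher numbers stand for weaker inhibition and lower numbers for stronger inhibition), compound 1 gives > 100000 nM, which is a limit of the assay and not a number. Compound 2 gives 1500 nM and compound 3 gives 13000 nM, so compound 3 holds the higher of the two actual numbers.

Compound 4 has not been measured. It has the same atoms as compound 3, joined differently: 2,4,6-trichlorophenyl in place of 2,4,5-trichlorophenyl on an oxygen, with 2,4,6-trichlorophenyl in place of 2,4,5-trichlorophenyl on an oxygen.

Among the compounds with values here, three measured steps bear on this group. The large at least 66-fold lower number from compound 1 to compound 2 (1.82 log units; beyond the scatter) came from methyl in place of hydrogen on an aromatic carbon. The modest 8.7-fold higher number from compound 2 to compound 3 (0.94 log units; beyond the scatter) and the at least modest an at least 7.6-fold lower number from compound 1 to compound 3 (0.88 log units; beyond the scatter) each exchanged the whole group. None of them keeps the atoms and only rejoins them, so they show that this group matters but give no direction here.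

No step beyond the scatter is expected in this assay, and the estimated change is a 1.4-fold lower number from compound 3 to compound 4 (0.16 log units; within the scatter). For compound 4 the estimate is 9000 nM, with an expected range from 2000 nM to 40000 nM.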

Compound 4, half-maximal inhibitory concentration: > 100000 nM
Compound 4 was reported as a limit; the forecaster's own chance of this, stated with the estimate: 7%; middle value at least 11-fold (1.04 log units) away from the limit.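

Moving one chlorine, with no atom gained or lost, gives an at least 7.6-fold higher number from compound 3 to compound 4 (0.88 log units; beyond the scatter) in this assay, so at this position the arrangement of the chlorines on the ring matters, and not only which atoms the group contains. Exchanging the 2,4-dimethylphenyl group for 2,4,6-trichlorophenyl on the same oxygen gives an at least 66-fold higher number from compound 2 to compound 4 (1.82 log units; beyond the scatter), while the step between compound 1 and compound 4 cannot be read. The value of compound 4 is a limit of the assay and not a number, and it is not the only one in this small set: the limit of > 100000 nM in this assay, at which 2 of the 4 values shown sit.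

The compounds shown cannot say whether the arrangement in 2,4,6-trichlorophenyl itself goes with this result or only does so when the three groups are chlorines, and a phenyl group carrying three methyl groups in the same arrangement on this oxygen would speak to that question. As far as these compounds go, how a phenyl ring carrying an amine or a carboxylic acid would behave in this place also remains open, as does whether the effect of moving the chlorine would persist with a longer chain in place of the propyl group.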